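A few compounds are considered here, and "the series" means these few. Any claim that something is new, unique, unknown or untested is made for them only; others in the source may bear on it.

Compound 1 `Cc1ccc(C#N)c(OC(C)(C)C2OCC(C/C=C\CCC(=O)O)C(c3cccnc3)O2)c1`: 15.9 nM
Compound 2 `CC(C)(C)c1ccc(OC(C)(C)C2OCC(C/C=C\CCC(=O)O)C(c3cccnc3)O2)cc1`: 1910 nM

Among the compounds with values here, in a functional assay for inhibition, with Homo sapiens as the target (on this read-out higher numbers stand for weaker binding and lower numbers for tighter binding), compound 2 stands highest of the two compounds measured so far. Compound 3 `CC(C)(Oc1ccc(F)cc1)C1OCC(C/C=C\CCC(=O)O)C(c2cccnc2)O1` has fluoro in place of tert-butyl on an aromatic carbon, para to a large group: fluoro in place of tert-butyl on an aromatic carbon. Within the data shown here, the one measured step that bears on this is a 120-fold higher number from compound 1 to compound 2 (2.08 log units; beyond the scatter), a large change beyond the scatter, in which the 4-(tert-butyl)phenyl group replaced 2-cyano-5-methylphenyl. A single step is thin support, but a move to a lower number is expected, with an expected size of a 9.6-fold lower number from compound 2 to compound 3 (0.98 log units; beyond the scatter). The estimate for compound 3 is 200 nM, with a range of 40 nM to 900 nM.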

Compound 3, dissociation constant: 120 nM
Compound 3: the middle estimate sits 1.7-fold (0.22 log units) above what was measured; the measured number falls inside the stated range.
By their numbers in this assay, from the lowest: compound 1; then compound 3; then compound 2.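

Replacing tert-butyl with fluoro while leaving the rest of the molecule unchanged gives a 16-fold lower number from compound 2 to compound 3 (1.20 log units; beyond the scatter), so this single place on the aromatic ring can by itself produce a large change. The earlier step had exchanged the whole aromatic group at once. The 4-fluorophenyl group still leaves a gap to 2-cyano-5-methylphenyl, with a 7.5-fold higher number from compound 1 to compound 3 (0.88 log units; beyond the scatter) as the step.

Going by these compounds, how an amine or a methoxy group would behave in place of fluoro stays open, as does the separate share of the nitrile and the methyl in compound 1. Nothing available explains why either step has the size it has.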